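Cytotoxicity notes: side chain on the ring amine

The source may hold more compounds than are shown below. What is called first, only, known or untested is meant among the compounds shown, and "the series" means these compounds.

Measured in an ADME assay on Vero cells (Chlorocebus sabaeus) for cytotoxicity, read by MTT assay, with a stated time of 72 h; a higher number here means that more compound is tolerated, a lower number that less compound is tolerated:
compound 1 `COc1c(N2CCN(CCC#N)C(C)C2)c(F)cc2c(=O)c(C(=O)O)cn(C3CC3)c12`: 500 ug/mL
compound 2 `CCOC(=O)CN1CCN(c2c(F)cc3c(=O)c(C(=O)O)cn(C4CC4)c3c2OC)CC1C`: 1000 ug/mL
compound 3 `CO/N=C(\C)CN1CCN(c2c(F)cc3c(=O)c(C(=O)O)cn(C4CC4)c3c2OC)CC1C`: 49.6 ug/mL

Compound 2 gives the highest of the three numbers in this assay, but its separation from compound 1 is only a 2.0-fold higher number from compound 1 to compound 2 (0.30 log units; within the scatter), which the scatter covers. Within the data shown here, compound 3 stands apart: the step of a 20-fold lower number from compound 2 to compound 3 (1.30 log units; beyond the scatter) and the step of a 10-fold lower number from compound 1 to compound 3 (1.00 log units; beyond the scatter) both run downward beyond the scatter, so the group carrying the carbon–nitrogen double bond is, so far, the one change on this side chain that lowers the tolerated concentration.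

Compound 4 `COc1c(N2CCN(C/C(C)=N/NC(C)=O)C(C)C2)c(F)cc2c(=O)c(C(=O)O)cn(C3CC3)c12` is the next member. Its change from compound 2: a group of 7 heavy atoms (4 carbon, 2 nitrogen, 1 oxygen; no ring) in place of a group of 5 heavy atoms (3 carbon, 2 oxygen; no ring), on a saturated chain carbon bound to an amine nitrogen in a ring. The entering group again carries a carbon–nitrogen double bond, now extended through a second nitrogen to an acetyl with one hydrogen-bond donor. Among the measured compounds shown here, no measured step covers this exact group; the closest precedent is compound 3, where a double-bonded nitrogen on the same saturated chain carbon brought a 20-fold lower number from compound 2 to compound 3 (1.30 log units; beyond the scatter). On that basis a downward step of similar size is expected, a 13-fold lower number from compound 2 to compound 4 (1.10 log units; beyond the scatter), with the donor an untested unknown. Compound 4 is therefore estimated at 80 ug/mL, in the range 25 ug/mL to 300 ug/mL.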

Compound 4, half-maximal cytotoxic concentration: 707 ug/mL
The estimate for compound 4 lay 8.8-fold (0.95 log units) below the measured number, outside the stated range (above it).
By their numbers in this assay, from the lowest: compound 3; then compounds 1, 4 and 2 (each within the scatter of the next).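

In this assay the carbon-nitrogen double bond on this side chain does not by itself bring a low number: with acetamido in place of methoxy on the double-bonded nitrogen, the step is a 14-fold higher number from compound 3 to compound 4 (1.15 log units; beyond the scatter), so what sits on that nitrogen makes a large difference at this position. The two remaining steps, a 1.4-fold lower number from compound 2 to compound 4 (0.15 log units; within the scatter) and a 1.4-fold higher number from compound 1 to compound 4 (0.15 log units; within the scatter), both stay within the scatter, so the larger group with the added hydrogen-bond donor cannot be told apart from ethoxycarbonyl or from the nitrile side chain in this read-out. No measurement at hand accounts for the gap between methoxy and acetamido on the double-bonded nitrogen.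

The compounds shown leave open whether the amide hydrogen of the acetamido group matters, and a hydroxyl or a free amine on the double-bonded nitrogen, or a methyl on the amide nitrogen, would bear on that. Also open, going by these compounds, is how a free carboxylic acid on the side chain, or a longer chain between the ring amine and the double-bonded carbon, would stand against these numbers.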